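The source may hold more compounds than are shown below. What is called first, only, known or untested is meant among the compounds shown, and "the series" means these compounds.

Measured compounds:
- compound 1 `Cc1cc(C)c(NC(=O)N(Cc2cccc(-c3nnn(C)n3)c2)C2CCCCCC2)c(C)c1` gives 100 nM in an assay on microsomes from intestine for inhibition of acyl-CoA:cholesterol acyltransferase (Oryctolagus cuniculus); on this read-out higher numbers stand for weaker inhibition and lower numbers for stronger inhibition
- compound 2 `Cc1cc(C)c(NC(=O)N(Cc2ccc(-c3cccnc3)cc2)C2CCCCCC2)c(C)c1` gives 130 nM in this assay
- compound 3 `Cc1cc(C)c(NC(=O)N(Cc2cccc(-c3cc[nH]n3)c2)C2CCCCCC2)c(C)c1` gives 65 nM in this assay

The three numbers lie close together. Compound 2 gives the largest of the three, yet its gap to compound 1 and its gap to compound 3 are both within the scatter, so nothing separates it from either. For the measured compounds named here, the only single-point step among them, a 1.5-fold lower number from compound 1 to compound 3 (0.19 log units; within the scatter), exchanges one five-membered heteroaryl for another and stays within the scatter.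

Compound 4 `Cc1cc(C)c(NC(=O)N(Cc2ccc(-n3cncn3)cc2)C2CCCCCC2)c(C)c1` differs from compound 2 by 1H-1,2,4-triazol-1-yl in place of pyridin-3-yl on an aromatic carbon. Going by the values given here, this again swaps one aromatic heterocycle for another on the shared core, and the one comparable step, from compound 1 to compound 3, moved nothing beyond the scatter. Among the compounds with values here, no measured pair speaks for a larger effect of such a swap, so the expected step of a 1.1-fold lower number from compound 2 to compound 4 (0.03 log units; within the scatter) in this assay is none beyond the scatter. Compound 4 is therefore estimated at 120 nM, with a range from 50 nM to 300 nM.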

Compound 4, half-maximal inhibitory concentration: 26 nM
The estimate for compound 4 lay 4.6-fold (0.66 log units) above the measured number, and the stated range ends above it.
By their numbers in this assay, from the lowest: compound 4; then compounds 3, 1 and 2 (each within the scatter of the next).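

At this place, para to a large group, the choice of aromatic heterocycle matters in this assay: 1H-1,2,4-triazol-1-yl in place of pyridin-3-yl gives a 5.0-fold lower number from compound 2 to compound 4 (0.70 log units; beyond the scatter), the first step among these compounds to pass the scatter. For the compounds shown here, the only earlier swap of heterocycles, a 1.5-fold lower number from compound 1 to compound 3 (0.19 log units; within the scatter), showed no such effect, so the two steps give no general rule for such swaps. No measurement at hand explains the new step.

In this one change a six-membered aromatic ring with 1 hetero atom gives way to a five-membered aromatic ring with 3 hetero atoms, so the compounds shown cannot separate ring size from the number of ring nitrogens. Also open, from the compounds shown here alone, is how 1H-imidazol-1-yl, a morpholin-4-yl amine or a carboxylic acid would fare at this place.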